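Swapping the Ring Group on the Nitrogen of Compound 2

The compounds below may be only part of what the source reports. "The series", "measured", "known", "first", "only" and "open" are said of these compounds alone.

Compound 1: `CSc1nc(-c2ccc(F)cc2)c(-c2ccnc(OCC3CCCCO3)c2)[nH]1` — a functional assay on blood (Homo sapiens) for inhibition; on this read-out lower numbers stand for stronger inhibition and higher numbers for weaker inhibition: "not determined" (no result reported)
Compound 2: `CSc1nc(-c2ccc(F)cc2)c(-c2ccnc(NC3CCCCC3C)c2)[nH]1` — this assay: 136 nM

Compound 1 has no reported result in this assay. Among the compounds with values here, compound 2 is the only compound with a number; in this assay compound 2 gives 136 nM. Compound 3 `CSc1nc(-c2ccc(F)cc2)c(-c2ccnc(NC(C)CCc3ccccc3)c2)[nH]1` differs from compound 2 in one place: 1-methyl-3-phenylpropyl in place of 2-methylcyclohexyl on a nitrogen on an aromatic ring. Within the data shown here, no step between measured compounds exists to calibrate this change. The group that leaves and the group that enters both carry no hydrogen-bond donors, no hydrogen-bond acceptors and no net charge, so a change of modest size, if any, in either direction is expected. Compound 3 is therefore estimated at 200 nM, with a range from 60 nM to 700 nM. That estimate means a step of a 1.5-fold higher number from compound 2 to compound 3 (0.17 log units; within the scatter), which is expected to stay within the usual scatter.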

Compound 3, half-maximal inhibitory concentration: 2370 nM
Compound 3: middle estimate off by 12-fold (1.07 log units), on the low side; measured number above the stated range.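

In this assay the group on this nitrogen clearly matters: 1-methyl-3-phenylpropyl in place of 2-methylcyclohexyl gives a 17-fold higher number from compound 2 to compound 3 (1.24 log units; beyond the scatter) and so a much weaker inhibitor, although neither group carries hydrogen-bond donors, acceptors or a net charge. Nothing available here accounts for a step of this size.

This single step swaps a non-aromatic ring for a chain ending in an aromatic ring, so it cannot separate those two features. As far as these compounds go, how a plain cyclohexyl or a benzyl group on this nitrogen would compare remains open.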